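Swapping the group on the oxygen of compound 2

This account rests on a few compounds, and the source may have more. Where it says the series, first, only, none or still open, it means among the compounds named here.

Compound 1 `CS(=O)(=O)Oc1ccc2c(c1)C(=O)C=CC2=O`: 17700 nM
Compound 2 `O=C1C=CC(=O)c2cc(Oc3ccco3)ccc21`: 17200 nM

In a functional assay on HeLa cells (Homo sapiens) for cytotoxicity (on this read-out lower numbers stand for stronger inhibition and higher numbers for weaker inhibition), compound 2 gives 17200 nM, level with compound 1 within the scatter. Compound 3 `CC(=O)Oc1ccc2c(c1)C(=O)C=CC2=O` carries acetyl in place of furan-2-yl on an oxygen on an aromatic ring. Going by the values given here, the one measured swap on this oxygen, a 1.0-fold lower number from compound 1 to compound 2 (0.01 log units; within the scatter), stayed within the scatter, so a second swap there is expected to show no step beyond the scatter in this assay. The expected step is a 1.1-fold lower number from compound 2 to compound 3 (0.03 log units; within the scatter). For compound 3 the estimate is 16000 nM, with an expected range from 7000 nM to 35000 nM.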

Compound 3, half-maximal inhibitory concentration: 27700 nM
For compound 3 the middle estimate is 1.7-fold (0.24 log units) below the measured one, within the range that was stated.
By their numbers in this assay, from the lowest: compounds 2, 1 and 3 (each within the scatter of the next).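

In this assay acetyl on the oxygen gives a 1.6-fold higher number from compound 2 to compound 3 (0.21 log units; within the scatter) and a 1.6-fold higher number from compound 1 to compound 3 (0.19 log units; within the scatter) and both steps stay within the scatter. Going by these compounds alone, this oxygen has now carried methylsulfonyl, furan-2-yl and acetyl, a ring and two groups without one, and no step among the three compounds goes beyond the scatter. No measured evidence explains this result.

As far as these compounds go, all three groups leave the shared core unchanged and sit on the same oxygen, so the effect of changes elsewhere remains open. From the compounds shown here alone, it is also open whether an amine or a carboxylic acid on a longer chain at this oxygen would shift the number beyond the scatter.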